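Isopropyl in Place of Phenoxy: What to Expect for Compound 4

The compounds below may be only part of what the source reports. "The series", "measured", "known", "first", "only" and "open" are said of these compounds alone.

Of the compounds shown here, three sharing one core have been measured in a functional assay on KB-V1 cells (Homo sapiens) for cytotoxicity, read by MTT assay, with a stated time of 72 h; a lower number here means a stronger inhibitor, a higher number a weaker inhibitor. Compound 1 `O=C1Nc2ccccc2/C1=N/NC(=S)Nc1ccc(Cl)cc1` gives 4990 nM. Compound 2 `CN(C)c1ccc(NC(=S)N/N=C2\C(=O)Nc3ccccc32)cc1` gives 2320 nM, and compound 3 `O=C1Nc2ccccc2/C1=N/NC(=S)Nc1ccc(Oc2ccccc2)cc1` gives 1670 nM. Among the compounds with values here, compound 3 thus stands at the low end of the three numbers, though its gap to compound 2, a 1.4-fold lower number from compound 2 to compound 3 (0.14 log units; within the scatter), lies within the scatter; only the step of a 3.0-fold lower number from compound 1 to compound 3 (0.48 log units; beyond the scatter) is beyond it, as is a 2.2-fold lower number from compound 1 to compound 2 (0.33 log units; beyond the scatter).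

Compound 4 `CC(C)c1ccc(NC(=S)N/N=C2\C(=O)Nc3ccccc32)cc1` differs from compound 3 in one place: isopropyl in place of phenoxy on an aromatic carbon. Within the data shown here, no measured pair trades phenoxy for isopropyl, so the two steps starting from compound 1 are the only guide, and both show that replacing chloro by dimethylamino or phenoxy lowers the number modestly. Isopropyl, bringing no ring and no acceptor, resembles neither. The number for compound 4 is therefore expected to move back toward that of compound 1, with the step of a 1.6-fold higher number from compound 3 to compound 4 (0.21 log units; within the scatter) estimated to lie near the edge of the scatter. The estimate for compound 4 is 2700 nM, within the range 1100 nM to 6500 nM.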

Compound 4, half-maximal inhibitory concentration: 1090 nM
The estimate for compound 4 lay 2.5-fold (0.39 log units) above the measured number; measured number below the stated range.
By their numbers in this assay, from the lowest: compounds 4, 3 and 2 (each within the scatter of the next, the first and the last beyond it); then compound 1.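

In this assay, within the data shown here, phenoxy, with its six-membered aromatic ring and its hydrogen-bond acceptor, gives way at this place to isopropyl, which has neither, and the result is a 1.5-fold lower number from compound 3 to compound 4 (0.19 log units; within the scatter) and so no step that can be told from repeat measurements. Isopropyl does separate from the other two groups, with a 2.1-fold lower number from compound 2 to compound 4 (0.33 log units; beyond the scatter) against dimethylamino and a 4.6-fold lower number from compound 1 to compound 4 (0.66 log units; beyond the scatter) against chloro as the largest step seen so far at this position. An aromatic ring and a hydrogen-bond acceptor in this group are therefore not required for a number in the range of compound 3.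

The compounds shown leave open whether a methyl group, a longer alkyl chain or a carboxylic acid at this place would hold the number there. Nothing measured alongside these numbers accounts for the result.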